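This account rests on a few compounds, and the source may have more. Where it says the series, first, only, none or still open, it means among the compounds named here.

Three compounds with a shared set of side groups and differently built cores have been tested in an ADME assay on microsomes from liver (Mus musculus) for metabolic stability, with a stated time of 10 min, tested at 1 uM; on this read-out higher numbers stand for a more stable compound and lower numbers for a less stable compound. There, compound 1 `Cc1cc(C(F)(F)F)ccc1-c1cc2cnn([C@@H](CC(C)C)c3ccc(C(=O)NCCC(=O)O)cc3)c2cc1C` gives 70%. Compound 2 `Cc1cc(C(F)(F)F)ccc1-c1cc2cn([C@@H](CC(C)C)c3ccc(C(=O)NCCC(=O)O)cc3)nc2cc1C` gives 79%, a value within the scatter of compound 1. Compound 3 `Cc1cc(C(F)(F)F)ccc1-c1ccc2nn([C@@H](CC(C)C)c3ccc(C(=O)NCCC(=O)O)cc3)cc2c1C` gives 50%, and compound 1 stands above it by a margin beyond the scatter. Compound 1 therefore sits in the upper part of this small set, level with compound 2 within the scatter.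

Compound 4 `Cc1cc2c(cnn2[C@@H](CC(C)C)c2ccc(C(=O)NCCC(=O)O)cc2)cc1-c1ccc(C(F)(F)F)cc1Cl` departs from compound 1 at one place: chloro in place of methyl on an aromatic carbon. It has chloro in place of methyl on an aromatic carbon, ortho to a large group and meta to a trifluoromethyl group, so 2-methyl-4-(trifluoromethyl)phenyl becomes 2-chloro-4-(trifluoromethyl)phenyl.

Among the measured compounds shown here, no tested pair shows this exchange on its own, so the data offer no direct precedent for it in this assay. With only one small substituent changed, no step beyond the scatter is expected, in either direction, and the starting point remains compound 1 at 70%. The estimated change is a number 2 percentage points higher from compound 1 to compound 4 (within the scatter), which is expected to stay within the scatter. For compound 4 the expected value is 72%, with an estimated range from 58% to 85%.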

Compound 4, percent of the compound remaining: 99%
The estimate for compound 4 lay 27 percentage points below the measured number; the whole stated range lies below it.
By their numbers in this assay, from the lowest: compound 3; then compounds 1 and 2 (each within the scatter of the next); then compound 4.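

In this assay, chloro in place of methyl on the aromatic carbon ortho to a large group and meta to a trifluoromethyl group gives a number 29 percentage points higher from compound 1 to compound 4 (beyond the scatter), so the change from 2-methyl-4-(trifluoromethyl)phenyl to 2-chloro-4-(trifluoromethyl)phenyl is not neutral on this read-out. Compounds 1, 2 and 3 all carry the same 2-methyl-4-(trifluoromethyl)phenyl group and differ only in the core, so they could not show that this position affects the read-out; here the exchange of one heavy atom, with no ring, hydrogen-bond donor, hydrogen-bond acceptor or net charge entering or leaving, produces a step beyond the scatter. Nothing reported for these compounds explains why the number rises. The compounds shown leave open whether the step follows from losing the methyl or from gaining the chloro, a question that fluoro, bromo, nitrile or methoxy at the same position could help to separate. They also leave open whether the same exchange would give a similar step on the cores of compound 2 and compound 3.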